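This account rests on a few compounds, and the source may have more. Where it says the series, first, only, none or still open, it means among the compounds named here.

The three measured compounds share one core and differ only in the amine on the sulfonyl sulfur. Compound 1 `CC(C)CN(CC(C)C)S(=O)(=O)c1ccc(NC(=O)C(C)(O)C(F)(F)F)cc1` carries a diisobutylamino group there, and in an assay on a protein complex (Cavia porcellus) with sulfonylurea receptors; K-ATP channels (Homo sapiens) as the target (a higher number here means a weaker inhibitor, a lower number a stronger inhibitor), compound 1 gives only a limit, > 30000 nM. Compound 2 `CN(C)S(=O)(=O)c1ccc(NC(=O)C(C)(O)C(F)(F)F)cc1` carries a dimethylamino group, and in this assay compound 2 gives 480 nM. Compound 3 `CC(O)(C(=O)Nc1ccc(S(=O)(=O)N2CCCCC2)cc1)C(F)(F)F` carries a piperidin-1-yl group, and in this assay compound 3 gives 9250 nM, the highest of the two numbers; compound 2 is nearest, with a 19-fold higher number from compound 2 to compound 3 (1.28 log units; beyond the scatter). Against the diisobutylamino group of compound 1 both changes lowered the number: an at least 62-fold lower number from compound 1 to compound 2 (1.79 log units; beyond the scatter) and an at least 3.2-fold lower number from compound 1 to compound 3 (0.51 log units; beyond the scatter).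

Compound 4 `CC(O)(C(=O)Nc1ccc(S(=O)(=O)N2CCCC2)cc1)C(F)(F)F` has not been measured in this assay. It differs from compound 3 in one place: pyrrolidin-1-yl in place of piperidin-1-yl on a sulfonyl sulfur. All three measured steps bear on this, since each swaps one amine on the sulfonyl sulfur for another, and within them the six-membered ring of compound 3 stands between the diisobutylamino and dimethylamino groups. The five-membered ring of compound 4 is therefore expected to bring a modest lowering, a 3.1-fold lower number from compound 3 to compound 4 (0.49 log units; beyond the scatter). For compound 4 in this assay the estimate is 3000 nM, with a range from 900 nM to 10000 nM.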

Compound 4, half-maximal inhibitory concentration: 880 nM
The estimate for compound 4 lay 3.4-fold (0.53 log units) above the measured number; the whole stated range lies above it.
By their numbers in this assay, from the lowest: compounds 2 and 4 (each within the scatter of the next); then compound 3. At a limit, above all of these: compound 1.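

In this assay, among the compounds shown here, the change from a six-membered to a five-membered ring on the sulfonyl sulfur gives an 11-fold lower number from compound 3 to compound 4 (1.02 log units; beyond the scatter), so this position responds sharply to ring size, which no earlier pair could show, and the pyrrolidin-1-yl ring of compound 4 matches the open-chain dimethylamino group of compound 2, with a 1.8-fold higher number from compound 2 to compound 4 (0.26 log units; within the scatter). A ring as such is therefore no obstacle here, and among the two rings shown the piperidin-1-yl ring of compound 3 is the one that goes with the higher number. Against the diisobutylamino group the pyrrolidin-1-yl ring gives an at least 34-fold lower number from compound 1 to compound 4 (1.53 log units; beyond the scatter), a step that can be read only as a bound. Compound 1 gives a limit of the assay and not a number: the limit of > 30000 nM in this assay, at which 1 of the 4 values shown sits.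

The compounds shown hold only two ring sizes, so it stays open where an azetidine or azepane ring on the sulfonyl sulfur would fall, and whether a morpholine ring would go with the pyrrolidin-1-yl or the piperidin-1-yl ring. As far as these compounds go, it also stays open whether a diethylamino group would stand with the dimethylamino group of compound 2 or closer to the diisobutylamino group of compound 1.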